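The source may hold more compounds than are shown below. What is called first, only, known or untested is meant among the compounds shown, and "the series" means these compounds.

Of the compounds shown here, two built on a shared core have so far been tested in an ADME assay on microsomes from liver (Mus musculus) for metabolic stability, read by mass spectrometry, with a stated time of 40 min, tested at 1 uM (on this read-out lower numbers stand for a less stable compound and higher numbers for a more stable compound), on their metabolic stability. There compound 1 `COc1cc(N2CCN(C(=O)N3CCC(O)C3)CC2)ccc1Nc1nc(NC2CCCCC2)c2nc[nH]c2n1` gives 47% and compound 2 `COc1cc(N2CCC(C(=O)N3CCC(N(C)C)C3)CC2)ccc1Nc1nc(NC2CCCCC2)c2nc[nH]c2n1` gives 60% as its reading. Compound 2 therefore holds the higher of the two numbers, and its gap to compound 1 lies beyond the usual scatter of repeated measurements.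

Compound 3 `CCN(CC)CC1CCN(c2ccc(Nc3nc(NC4CCCCC4)c4nc[nH]c4n3)c(OC)c2)CC1` has not yet been measured. On a saturated ring carbon of a six-membered non-aromatic ring with 1 nitrogen, it carries (diethylamino)methyl in place of the (3-(dimethylamino)pyrrolidin-1-yl)carbonyl of compound 2, a change summed up as (diethylamino)methyl in place of (3-(dimethylamino)pyrrolidin-1-yl)carbonyl on a saturated ring carbon in full. Among the compounds with values here, no two measured compounds differ in only one place, so no measured step speaks directly to this change. With compound 2 at 60% as the higher of just two numbers, a lower reading seems more likely than a higher one. In this assay a moderate fall is expected, with an estimated step of a number 15 percentage points lower from compound 2 to compound 3 (beyond the scatter) of a size just past the scatter. The estimate for compound 3 is 45% within an expected range from 25% to 65% for a single measurement.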

Compound 3, percent of the compound remaining: 47%
Beside the measured number, compound 3's estimate is 2 percentage points below it; measured number inside the range.
By their numbers in this assay, from the lowest: compounds 1 and 3 (each within the scatter of the next); then compound 2.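

Within the data shown here, exchanging (3-(dimethylamino)pyrrolidin-1-yl)carbonyl for (diethylamino)methyl on a saturated ring carbon gives the first comparison in this assay between compounds that differ in only one place, and the reading comes out a number 13 percentage points lower from compound 2 to compound 3 (beyond the scatter). This modest step shows that the group at this position matters for the reading, with the larger group, which has a ring and a carbonyl, going with more compound remaining in this single pair. Nothing measured here explains why the reading moves, and a single pair cannot show a general pattern.

This change removes the five-membered ring and the carbonyl together and also alters the groups on the amine nitrogen, so the step cannot be assigned to any one of these parts. On these data alone, whether (diethylamino)carbonyl, which keeps the carbonyl but has no ring, or (3-(dimethylamino)pyrrolidin-1-yl)methyl, which keeps the ring but has no carbonyl, would read closer to compound 2 or to compound 3 remains open.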